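The compounds below may be only part of what the source reports. "The series", "measured", "known", "first", "only" and "open" are said of these compounds alone.

Compound 1 `COc1ccc(-c2nc3ccccc3s2)cc1NC(=O)c1cnccc1Cl` was examined in an ADME assay on HEK293 cells (Homo sapiens) for inhibition, with a stated time of 72 h; a higher number here means that more compound is needed for the effect, a lower number that less compound is needed. In this assay compound 1 gives > 25000 nM, which is a limit of the assay and not a number. Compound 2 `O=C(Nc1cc(-c2nc3ccccc3s2)ccc1F)c1cnccc1Cl` differs from it by a fluoro in place of methoxy on an aromatic carbon. In this assay compound 2 gives > 25000 nM, also a limit. The step that the two limits leave unreadable from compound 1 to compound 2 is therefore unreadable in size, since both values sit at the limit of > 25000 nM in this assay, at which 2 of the 2 values shown sit. Among the measured compounds shown here, no measured step gives a readable direction, so nothing beyond the scatter can be inferred from the pair. Compound 3 `COc1ccc(-c2nc3ccccc3o2)cc1NC(=O)c1cnccc1Cl` has not been measured; it differs from compound 1 by 1,3-benzoxazol-2-yl in place of 1,3-benzothiazol-2-yl on an aromatic carbon, meta to a large group and para to a methoxy group. Because compound 1 rests at the limit of > 25000 nM in this assay, at which 2 of the 2 values shown sit, compound 3 is expected to remain near that limit, with an expected step that the limit leaves unreadable from compound 1 to compound 3 and an estimate of 30000 nM ranging from 8000 nM to 100000 nM.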

Compound 3, half-maximal effective concentration: > 25000 nM
Compound 3 gave a limit, no number (the forecaster's own chance of this, stated with the estimate: 80%); the middle value does not contradict the limit.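

In this assay compound 3 gives only a limit, as compound 1 does, so the size of the step to 1,3-benzoxazol-2-yl in place of 1,3-benzothiazol-2-yl cannot be read: the limit of > 25000 nM in this assay, at which 3 of the 3 values shown sit. The compounds shown leave open how either change acts in this assay, for none gives a number.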